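Swapping a Urea Tail for Pyridine: Cytotoxicity Outlook

A few compounds are considered here, and "the series" means these few. Any claim that something is new, unique, unknown or untested is made for them only; others in the source may bear on it.

This set of compounds was tested in an ADME assay on cells (Homo sapiens) for cytotoxicity, read by polymerase chain reaction, with a stated time of 3 days; a higher number here means that more compound is tolerated, a lower number that less compound is tolerated. Compound 1 `Nc1nc(Cl)c(-c2nc3ccc(F)cc3s2)c(N[C@@H]2C[C@H](CO)[C@@H](O)[C@H]2O)n1` gave only a limit of the assay, > 25000 nM, and not a number. Compound 2 `CNc1ccc2sc(-c3c(Cl)nc(N)nc3N[C@@H]3C[C@H](CO)[C@@H](O)[C@H]3O)nc2c1` gave 20000 nM. Compound 3 `Cc1nc(NCCNC(=O)NC(C)(C)C)nc(N[C@@H]2C[C@H](CO)[C@@H](O)[C@H]2O)c1-c1nc2ccccc2s1` also reached only a limit of the assay, > 25000 nM, so no number is known for it. Compound 3 therefore stands at the limit of > 25000 nM in this assay, at which 2 of the 3 values shown sit, the top of what was shown here, and no step between measured compounds that differ in one place exists to lean on.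

Compound 4 `Cc1nc(NCc2ccncc2)nc(N[C@@H]2C[C@H](CO)[C@@H](O)[C@H]2O)c1-c1nc2ccccc2s1` is the next one to be measured. Among the measured compounds shown here, its only difference from compound 3 is pyridin-4-yl in place of (((tert-butyl)carbamoyl)amino)methyl on a saturated chain carbon bound to a nitrogen on an aromatic ring. With no measured step of this kind in hand, the expectation for the step from compound 3 to compound 4 is none beyond the usual scatter, an at least 1.1-fold lower number from compound 3 to compound 4 (0.05 log units; that floor lies within the scatter), and an expected result near the limit again. Compound 4 is therefore estimated at 22000 nM, expected to fall between 7000 nM and 50000 nM.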

Compound 4, half-maximal cytotoxic concentration: 7000 nM
Compound 4: the middle estimate sits 3.1-fold (0.50 log units) above what was measured, within the range that was stated.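

In this assay, replacing (((tert-butyl)carbamoyl)amino)methyl with pyridin-4-yl on a saturated chain carbon bound to a nitrogen on an aromatic ring gives an at least 3.5-fold lower number from compound 3 to compound 4 (0.55 log units; beyond the scatter). Among the compounds shown here, this is the first measured step in the set, and it shows that the group at this place can change how much compound the cells tolerate, with the shared core unchanged. Compound 3 gave a limit and not a number, so the full size of the step stays unknown because only a floor can be read from it: the limit of > 25000 nM in this assay, at which 2 of the 4 values shown sit.

The compounds shown leave open whether the lower number comes with the pyridin-4-yl ring itself or with the loss of the tert-butyl urea tail. A phenyl ring or a simple amine at the same place would help to separate these two readings.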